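This account rests on a few compounds, and the source may have more. Where it says the series, first, only, none or still open, it means among the compounds named here.

Compound 1 `Nc1nc(SCc2ccccc2)[nH]c(=O)c1N(Cc1ccccc1)Cc1ccccc1` and compound 2 `CCn1c(SCc2ccccc2)nc(N)c(N(Cc2ccccc2)Cc2ccccc2)c1=O` share a core and differ by ethyl in place of hydrogen on an aromatic nitrogen. In a functional assay on cardiac atrium (Cavia porcellus) (a higher number here means that more compound is needed for the effect, a lower number that less compound is needed), compound 1 gives 3160 nM, while compound 2 gives 450 nM; this change made a 7.0-fold lower number from compound 1 to compound 2 (0.85 log units; beyond the scatter). Compound 3 `CCCSc1nc(NC(C)=O)c(N(CCC)CCC)c(=O)[nH]1` is built on another core, and how it differs from compound 1 is not broken down here. In this assay compound 3 gives 280 nM, a number that lies within the usual scatter of compound 2 and beyond it from compound 1. Compound 4 `CCCSc1nc(NC(C)=O)c(N(CCC)CCC)c(=O)n1CC` has not yet been measured and differs from compound 3 by ethyl in place of hydrogen on an aromatic nitrogen. Within the data shown here, this is the same kind of change as the one between compound 1 and compound 2, though the place is not identical: in compound 3 the ring nitrogen is ortho to a propylsulfanyl group, meta to a dipropylamino group and para to an acetamido group, whereas in compound 1 it is ortho to a benzylsulfanyl group, meta to a large group and para to an amino group. Because the earlier change produced a 7.0-fold lower number from compound 1 to compound 2 (0.85 log units; beyond the scatter), a step of comparable direction is expected for compound 4, a 4.0-fold lower number from compound 3 to compound 4 (0.60 log units; beyond the scatter), with the expectation resting on that single pair only, made on a different core. Compound 4 is therefore estimated at 70 nM, between 25 nM and 250 nM.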

Compound 4, half-maximal effective concentration: 530 nM
Estimate against measurement, compound 4: 7.6-fold (0.88 log units) below; measured number outside the range, above it.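

In this assay, ethyl in place of hydrogen on an aromatic nitrogen gives a 1.9-fold higher number from compound 3 to compound 4 (0.28 log units; within the scatter), so on the core of compound 3 the change has no effect that can be told from the scatter. The lower number seen with this change on the core of compound 1 did not carry over, and the two outcomes differ: the same change on two cores in this assay, a 7.0-fold lower number (0.85 log units; beyond the scatter) from compound 1 to compound 2 and a 1.9-fold higher number (0.28 log units; within the scatter) from compound 3 to compound 4, 13-fold (1.12 log units) apart, beyond the scatter of two such steps. Among these compounds, this shows that the step cannot be carried between these two cores as a fixed amount, but it does not show which difference between the cores matters, as the propylsulfanyl, dipropylamino and acetamido groups all stand where the core of compound 1 carries other groups, and each core offers only one pair.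

The compounds shown leave open how a methyl group or a longer chain such as butyl on that ring nitrogen would behave on either core. They also leave open whether an amino group in place of the acetamido group would bring back the step seen on the core of compound 1.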